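A few compounds are considered here, and "the series" means these few. Any claim that something is new, unique, unknown or untested is made for them only; others in the source may bear on it.

Measured in a physicochemical assay for solubility, at pH 7.4; a higher number here means a more soluble compound, a lower number a less soluble compound:
- Compound 1 `CC1(c2nc(-c3ccc(CNC(=O)[C@H]4NCC[C@@H]4O)cc3)no2)CCCCC1`: > 50 ug/mL (a limit of the assay, not a number)
- Compound 2 `O=C(NCc1ccc(-c2noc(CCC3CC3)n2)cc1)[C@H]1NCC[C@@H]1O`: > 50 ug/mL (a limit of the assay, not a number)
- Compound 3 `O=C(NCc1ccc(-c2noc(CCC3CCCCC3)n2)cc1)[C@H]1NCC[C@@H]1O`: 26 ug/mL

Compound 3 is the only one of the three with a true number. Compound 1 and compound 2 share the limit of > 50 ug/mL in this assay, at which 2 of the 3 values shown sit, and so cannot be ranked against each other.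

Compound 4 `O=C(NCc1ccc(-c2noc(C3CCCCC3)n2)cc1)[C@H]1NCC[C@@H]1O` carries cyclohexyl in place of 2-cyclohexylethyl on an aromatic carbon. The ring stays and the chain linking it goes.

Within the data shown here, two measured steps bear on this. Putting 2-cyclohexylethyl in place of 1-methylcyclohexyl gave an at least 1.9-fold lower number from compound 1 to compound 3 (0.28 log units; that floor lies within the scatter), and putting cyclohexyl in place of cyclopropyl on the chain gave an at least 1.9-fold lower number from compound 2 to compound 3 (0.28 log units; that floor lies within the scatter). The first is the closer guide, since the change to compound 4 runs roughly the opposite way. The expected step is therefore small and upward if anything, namely a 1.7-fold higher number from compound 3 to compound 4 (0.24 log units; within the scatter) in this assay as estimated here. Compound 4 is estimated at 45 ug/mL, with an expected range from 22 ug/mL to 90 ug/mL here.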

Compound 4, solubility: > 50 ug/mL
Compound 4: no number, only a limit; the forecaster's own chance of this, stated with the estimate: 40%; at least 1.1-fold (0.04 log units) between middle value and limit.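

In this assay, keeping the cyclohexyl ring while losing the chain that links it to the aromatic carbon gives an at least 1.9-fold higher number from compound 3 to compound 4 (0.28 log units; that floor lies within the scatter). For compound 4, > 50 ug/mL is a limit of the assay and not a number, so this step is only a floor, and the true size of the change could be larger. The other two steps to compound 4 cannot be read, since both ends of each are limits: the limit of > 50 ug/mL in this assay, at which 3 of the 4 values shown sit.

Still open, as far as these compounds go, is how compound 1, compound 2 and compound 4 rank against one another, and whether the true step to compound 4 lies beyond the scatter. Also open, from the compounds shown here alone, is what an amine or a carboxylic acid in place of cyclohexyl, or a longer chain carrying the cyclohexyl ring, would do at this position.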